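A few compounds are considered here, and "the series" means these few. Any claim that something is new, unique, unknown or untested is made for them only; others in the source may bear on it.

Compound 3 `O=C(NSc1ccccc1)[C@@H](CCC(F)(F)F)N(Cc1ccc(-c2ncon2)cc1F)S(=O)(=O)c1ccc(Cl)cc1` stands at the low edge of the values gathered so far. In a physicochemical assay for solubility, at pH 2 (on this read-out higher numbers stand for higher solubility and lower numbers for lower solubility), compound 3 gives < 1 ug/mL, which is a limit of the assay and not a number (the limit of < 1 ug/mL in this assay, at which 1 of the 3 values shown sits). Compound 1 `NCCSNC(=O)[C@@H](CCC(F)(F)F)N(Cc1ccc(-c2ncon2)cc1F)S(=O)(=O)c1ccc(Cl)cc1` marks the opposite edge. In this assay compound 1 gives > 10000 ug/mL, again a limit rather than a number (the limit of > 10000 ug/mL in this assay, at which 1 of the 3 values shown sits). Compound 2 `N[C@@H](CSNC(=O)[C@@H](CCC(F)(F)F)N(Cc1ccc(-c2ncon2)cc1F)S(=O)(=O)c1ccc(Cl)cc1)C(=O)O` lies between the two, and in this assay compound 2 gives 510 ug/mL.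

Compound 4 `N#CCCSNC(=O)[C@@H](CCC(F)(F)F)N(Cc1ccc(-c2ncon2)cc1F)S(=O)(=O)c1ccc(Cl)cc1` differs from compound 3 in one place: 2-cyanoethyl in place of phenyl on a sulfur. Among the compounds with values here, two measured steps bear on this exchange at the sulfur. an at least 10000-fold lower number from compound 1 to compound 3 (4.00 log units; beyond the scatter) and an at least 510-fold lower number from compound 2 to compound 3 (2.70 log units; beyond the scatter) both show that phenyl on the sulfur, in place of a short chain, went with a large drop. Compound 4 removes that phenyl and brings in a chain once more, though one without the amine of the 2-aminoethyl in compound 1 or the amine and carboxy of the 2-amino-2-carboxyethyl in compound 2. A rise in this assay is therefore expected, and the estimated step is an at least 50-fold higher number from compound 3 to compound 4 (1.69 log units; beyond the scatter), smaller than the reverse of either measured step. Compound 4 is estimated to give 50 ug/mL in this assay, with a range from 5 ug/mL to 500 ug/mL.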

Compound 4, solubility: < 1 ug/mL
Compound 4 gave a limit, no number; the forecaster's own chance of this, stated with the estimate: 15%; middle value at least 50-fold (1.69 log units) away from the limit.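

The exchange at the sulfur separates two things that compound 1, compound 2 and compound 3 had left together: a short chain in place of phenyl does not by itself lift the read-out in this assay, and compound 4, with its 2-cyanoethyl, sits at the same limit as compound 3: the limit of < 1 ug/mL in this assay, at which 2 of the 4 values shown sit. The step between these two cannot be read, since both values are limits. Against the chains that carry an amine, the nitrile chain stands far lower, with an at least 510-fold lower number from compound 2 to compound 4 (2.70 log units; beyond the scatter) and an at least 10000-fold lower number from compound 1 to compound 4 (4.00 log units; beyond the scatter), so among the compounds shown only the chains with an amine come off that limit.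

On these data alone, how far under the limit compound 3 and compound 4 lie stays open, and with it any difference between phenyl and 2-cyanoethyl on the sulfur. Also open, as far as these compounds go, is how a carboxylic acid on the chain without the amine, or an amine at the end of a longer chain, would stand in this assay.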